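The source may report more compounds than this note shows. Statements on the series, on what has been measured and on what is new or still open speak of the compounds shown alone.

Measured so far in the series:

Compound 1 `COc1ccc(-c2[nH]c3ccccc3c2/C=C(\C#N)S(=O)(=O)c2ccccc2)cc1` — in a functional assay on SK-MEL-2 cells (Homo sapiens) for inhibition, read by sulforhodamine B assay, with a stated time of 48 h (a higher number here means a weaker inhibitor of growth, a lower number a stronger inhibitor of growth), compound 1 gives 18100 nM.
Compound 2 `COc1ccc(-c2[nH]c3ccc(OC)cc3c2/C=C(\C#N)S(=O)(=O)c2ccccc2)cc1` — in this assay compound 2 gives 9000 nM.

Compound 2 sits at the low end of the two numbers shown, but the only step joining it to a neighbour, a 2.0-fold lower number from compound 1 to compound 2 (0.30 log units; within the scatter), lies within the scatter, so the two compounds cannot be told apart on these data.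

The next compound, compound 3 `COc1ccc2[nH]c(-c3ccccc3)c(/C=C(\C#N)S(=O)(=O)c3ccccc3)c2c1`, differs from compound 2 by hydrogen in place of methoxy on an aromatic carbon; the same difference, cut one bond further out, reads 4-methoxyphenyl to phenyl. For the measured compounds named here, no measured step touches this methoxy. Going by the values given here, the one step available, a 2.0-fold lower number from compound 1 to compound 2 (0.30 log units; within the scatter), concerns a methoxy elsewhere in the molecule and stayed within the scatter, so it bears on the present change only loosely. On that basis no move beyond the scatter is expected in this assay for compound 3, and the expected step is a 1.2-fold higher number from compound 2 to compound 3 (0.09 log units; within the scatter). Compound 3 is therefore estimated at 11000 nM, with a range from 4500 nM to 27000 nM.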

Compound 3, concentration for 50% growth inhibition: 3700 nM
Estimate against measurement, compound 3: 3.0-fold (0.47 log units) above, outside the stated range (below it).
By their numbers in this assay, from the lowest: compound 3; then compounds 2 and 1 (each within the scatter of the next).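

In this assay, the change from 4-methoxyphenyl to phenyl gives a 2.4-fold lower number from compound 2 to compound 3 (0.39 log units; beyond the scatter), a modest step but the first in the series to lie beyond the scatter. This methoxy, on an aromatic carbon para to a large group, therefore makes a readable difference, and hydrogen in its place goes with the stronger growth inhibition, whereas the other methoxy, in a 2.0-fold lower number from compound 1 to compound 2 (0.30 log units; within the scatter), made no difference that can be read. The finding rests on this single pair, and nothing measured on these compounds accounts for the step.

The compounds shown leave open whether the same change gives a similar step on the core of compound 1, which lacks the second methoxy. They also leave open whether hydrogen is favoured at this position over other small groups or the methoxy is specifically disfavoured, a question that a hydroxy group, a chlorine atom or an amine in the same place would help to separate.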